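The source may hold more compounds than are shown below. What is called first, only, known or untested is meant among the compounds shown, and "the series" means these compounds.

Among the compounds with values here, in a functional assay on CHO cells for agonist activity at Free fatty acid receptor 2 (Homo sapiens), read by cAMP accumulation (on this read-out higher numbers stand for larger maximal responses and lower numbers for smaller maximal responses), compound 2 `CC(C)[C@H](C(=O)Nc1ccccn1)c1ccc(Cl)cc1` gives 92%, the only plain number among the two values shown. The other value belongs to compound 1 `CC(C)[C@H](C(=O)NC(C)(C)C)c1ccc(Cl)cc1`, which in this assay gives < 30%, a limit of the assay rather than a number. Within the data shown here, the one measured step, a number at least 62 percentage points higher from compound 1 to compound 2 (beyond the scatter), is large, but it concerns the group carried by the amide-type nitrogen. Compound 3 `CC(C)[C@H](C(=O)Nc1ccc(F)cn1)c1ccc(Cl)cc1` differs from compound 2 at another place: fluoro in place of hydrogen on an aromatic carbon. Among the measured compounds shown here, no measured step touches the pyridin-2-yl ring itself, so there is no direct guide from the data for this change, and the measured step on the nitrogen substituent does not transfer to it. The expected step, a number 7 percentage points lower from compound 2 to compound 3 (within the scatter), therefore stays within the usual scatter. Compound 3 is thus estimated to give 85% in this assay, most likely between 60% and 100%.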

Compound 3, largest response reached (reported as efficacy), in percent of the reference or control that the assay uses: 93%
Compound 3: middle estimate off by 8 percentage points, on the low side, within the range that was stated.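

In this assay, fluoro can replace hydrogen on this carbon of the pyridin-2-yl ring, two atoms from the ring nitrogen, with no change beyond the scatter: the swap gives a number 1 percentage points higher from compound 2 to compound 3 (within the scatter). The large gain over the tert-butyl amide also survives this change, since 5-fluoropyridin-2-yl in place of tert-butyl gives a number at least 63 percentage points higher from compound 1 to compound 3 (beyond the scatter). That step has only a lower bound, not an exact size, as compound 1 is known only through a limit of the assay: the limit of < 30% in this assay, at which 1 of the 3 values shown sits.

A single fluoro cannot show how a chloro, a methoxy or an amine at the same carbon would behave. As far as these compounds go, whether fluoro is tolerated equally on the other carbons of the ring also remains open.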